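Methoxy to hydroxy change, second instance in the series

This account rests on a few compounds, and the source may have more. Where it says the series, first, only, none or still open, it means among the compounds named here.

Measured so far:
Compound 1 `COc1cc(-c2nn(-c3cccc(NC(=O)Nc4cc(C(F)(F)F)cc(C(F)(F)F)c4)c3)cc2-c2ccncc2)ccc1Cl`: in a functional assay on T47D cells (Homo sapiens) for inhibition, read by sulforhodamine B assay, with a stated time of 48 h (on this read-out higher numbers stand for lower toxicity in this test and lower numbers for higher toxicity in this test), compound 1 gives only a limit, > 50000 nM.
Compound 2 `O=C(Nc1cccc(-n2cc(-c3ccncc3)c(-c3ccc(Cl)c(O)c3)n2)c1)Nc1cc(C(F)(F)F)cc(C(F)(F)F)c1`: in this assay compound 2 gives only a limit, > 50000 nM.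
Compound 3 `COc1cc(-c2nn(-c3cccc(NC(=O)Nc4ccc(Cl)c(C(F)(F)F)c4)c3)cc2-c2ccncc2)ccc1Cl`: in this assay compound 3 gives only a limit, > 32500 nM.

The change from compound 1 to compound 2 is hydrogen in place of methyl on an oxygen on an aromatic ring. Since both ends are limits, the step that the two limits leave unreadable from compound 1 to compound 2 stays unreadable in size. Compound 3 carries a different core; the difference between the two cores is not broken down here. Compound 4 `O=C(Nc1cccc(-n2cc(-c3ccncc3)c(-c3ccc(Cl)c(O)c3)n2)c1)Nc1ccc(Cl)c(C(F)(F)F)c1` repeats the same change on compound 3, namely (hydrogen in place of methyl on an oxygen on an aromatic ring). Across the three values, two sit at the limit of > 50000 nM in this assay, at which 2 of the 3 values shown sit, and one at the limit of > 32500 nM in this assay, at which 1 of the 3 values shown sits, so no number in this assay is available anywhere in this set.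

Going by the values given here, with every measured value a limit and the only matched step unreadable, compound 4 is expected to stay at or near a limit as well, and the expected step that the limit leaves unreadable from compound 3 to compound 4 is set at essentially no change. The estimate for compound 4 in this assay is 50000 nM, with a range from 20000 nM to 100000 nM.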

Compound 4, concentration lethal to 50% of the cells: > 32500 nM
Compound 4 was reported as a limit; the forecaster's own chance of this, stated with the estimate: 85%; the middle value lies beyond the limit too.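

The methoxy to hydroxy step between compound 3 and compound 4 cannot be read: each compound gives only a limit in this assay. The compounds shown leave open where any of the four actually lies in this assay, and whether methoxy to hydroxy changes the read-out at all in either matched pair.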